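Shrinking the Ring on an Amide Nitrogen

The compounds below may be only part of what the source reports. "The series", "measured", "known", "first", "only" and "open" are said of these compounds alone.

Of the compounds shown here, two have been measured in an assay on CHO cells for displacement of a labelled ligand from adenosine receptor A1 (Homo sapiens), read by scintillation counting, with a stated time of 60 min, tested at 10 uM; on this read-out higher numbers stand for more inhibition at the one concentration tested (going by the name of the read-out) and lower numbers for less inhibition. Compound 1 `O=C(NCC(O)CO)c1cc2cc(Cl)ccc2oc1=O` gives 21%. Compound 2 `COc1cccc2cc(C(=O)NC3CCCCC3)c(=N)oc12` gives 40%, the higher of the two numbers, and its gap to compound 1 lies beyond the usual scatter. Compound 3 `COc1cccc2cc(C(=O)NC3CCCC3)c(=N)oc12` has not yet been measured; it differs from compound 2 in one place: cyclopentyl in place of cyclohexyl on an amide-type nitrogen. Going by the values given here, no pair of measured compounds shows how such a change plays out, so in this assay only a small step, or none beyond the scatter, is expected, if anything a slight drop. Compound 3 is thus expected to give around 35%, between 15% and 55%. The expected step is a number 5 percentage points lower from compound 2 to compound 3 (within the scatter).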

Compound 3, a percentage reported as inhibition, at one concentration (the size of the read-out at that concentration, not a potency): > 70%
Compound 3: no number, only a limit; the forecaster's own chance of this, stated with the estimate: 0%; middle value at least 35 percentage points away from the limit.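

On the amide-type nitrogen, ring size matters: in this assay, cyclopentyl in place of cyclohexyl gives a number at least 30 percentage points higher from compound 2 to compound 3 (beyond the scatter). Going by these compounds alone, the earlier compounds differ in more than one place, so only this pair shows that going from a six-membered to a five-membered carbon ring can by itself move the read-out. The result for compound 3 is a limit of the assay and not a number: the limit of > 70% in this assay, at which 1 of the 3 values shown sits.

From the compounds shown here alone, whether a smaller cyclobutyl ring, an open isopropyl chain or a cyclopentyl ring carrying an amine would hold this level stays open. The compounds shown also give no potency, since the read-out comes from one concentration.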